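Azetidine-linked amides: pyridyl to pyrazolyl carbonyl swap

This account rests on a few compounds, and the source may have more. Where it says the series, first, only, none or still open, it means among the compounds named here.

Measured so far:
compound 1 `Cc1ccncc1C(=O)N1CC(Oc2cncc(N3C(=O)c4ccc(Cl)cc4C3(C)C)c2)C1` — 15.8 mL/min/kg
compound 2 `Cn1cc(C(=O)N2CC3(C2)CN(c2cncc(N4C(=O)c5ccc(Cl)cc5C4(C)C)c2)C3)cn1` — 6.4 mL/min/kg

In an ADME assay on the whole organism (Rattus norvegicus, strain Wister-Han) for pharmacokinetics, read by LC-MS, at a dose of 1 mg/kg by the intravenous route (a higher number here means faster removal of the compound, a lower number slower removal), compound 1 gives the higher of the two numbers; compound 2 sits lower by a gap beyond the scatter. Compound 3 `Cn1cc(C(=O)N2CC(Oc3cncc(N4C(=O)c5ccc(Cl)cc5C4(C)C)c3)C2)cn1` keeps the core of compound 1 and carries the change (1-methyl-1H-pyrazol-4-yl in place of 4-methylpyridin-3-yl on a carbonyl carbon). Among the compounds with values here, no measured pair isolates this change, so the direction is taken from compound 2, which bears the same 1-methyl-1H-pyrazol-4-yl carbonyl and gives 6.4 mL/min/kg in this assay. A moderate fall is expected, a 1.7-fold lower number from compound 1 to compound 3 (0.22 log units; within the scatter), reaching the edge of the scatter. Compound 3 is estimated at 9.5 mL/min/kg, within 5 mL/min/kg to 17 mL/min/kg.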

Compound 3, clearance: 3.8 mL/min/kg
Compound 3: middle estimate off by 2.5-fold (0.40 log units), on the high side, outside the stated range (below it).
By their numbers in this assay, from the lowest: compounds 3 and 2 (each within the scatter of the next); then compound 1.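

In this assay, 1-methyl-1H-pyrazol-4-yl in place of 4-methylpyridin-3-yl on a carbonyl carbon gives a 4.2-fold lower number from compound 1 to compound 3 (0.62 log units; beyond the scatter). Within the data shown here, this is the first direct reading of the change with the core of compound 1 held fixed, and it shows that this group alone can move the number beyond the scatter. No data at hand bear on the cause of the shift.

Still open, on these data alone, is where other groups on this carbonyl carbon would fall, such as phenyl or pyridin-3-yl without the methyl, relative to compound 1 and compound 3.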